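Piperazin-1-yl for Acetyl: Expected Clearance of Compound 3

The compounds below may be only part of what the source reports. "The series", "measured", "known", "first", "only" and "open" are said of these compounds alone.

Measured compounds:
compound 1, `CNc1nc(NCCCN(C)C)c2sc(-c3ccc(-n4cccn4)cc3)cc2n1`: 18.4 uL/min
compound 2, `CNc1nc(NCCCN(C)C)c2sc(-c3ccc(C(C)=O)cc3)cc2n1`: 81 uL/min

In an ADME assay (liver) for metabolic stability, with Liver microsome (Homo sapiens) as the target, read by LC-MS, using microsomes, tested at 1 uM (a lower number here means slower removal, a higher number faster removal of the compound), compound 1 gives 18.4 uL/min. In the same assay compound 2 gives 81 uL/min. Going by the values given here, compound 2 thus stands highest of the two numbers, and its only neighbour is compound 1, separated by a 4.4-fold higher number from compound 1 to compound 2 (0.64 log units; beyond the scatter).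

Compound 3, `CNc1nc(NCCCN(C)C)c2sc(-c3ccc(N4CCNCC4)cc3)cc2n1`, differs from compound 2 in one place: piperazin-1-yl in place of acetyl on an aromatic carbon. Among the compounds with values here, only one measured step touches this change, and only loosely. The step of a 4.4-fold higher number from compound 1 to compound 2 (0.64 log units; beyond the scatter) shows the acetyl arriving together with a modest rise in clearance, so its departure is read as pointing toward a lower number; nothing measured speaks to the piperazin-1-yl itself, so the size is uncertain. For compound 3 the expected step is a 2.7-fold lower number from compound 2 to compound 3 (0.43 log units; beyond the scatter). Compound 3 is therefore estimated at 30 uL/min, within a range from 12 uL/min to 75 uL/min.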

Compound 3, intrinsic clearance in a liver preparation (reported as CLH), per the amount of preparation that the assay uses: 36 uL/min
Compound 3: the middle estimate sits 1.2-fold (0.08 log units) below what was measured; low and high end bracket the measured number.
By their numbers in this assay, from the lowest: compounds 1 and 3 (each within the scatter of the next); then compound 2.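

In this assay, the place on the six-membered aromatic ring of carbon only now has a third group, and the acetyl is no longer set apart from a single partner: replacing it with piperazin-1-yl gives a 2.3-fold lower number from compound 2 to compound 3 (0.35 log units; beyond the scatter). The second ring group cannot be told apart from the first, as the change from 1H-pyrazol-1-yl to piperazin-1-yl gives a 2.0-fold higher number from compound 1 to compound 3 (0.29 log units; within the scatter), even though one ring is aromatic and the other is not. No available evidence explains why either ring group differs from the acetyl.

Going by these compounds, it remains open whether an open-chain amine or a carboxylic acid at this place would group with compound 1 and compound 3 or with compound 2. Whether another ketone would match the acetyl also remains unsettled.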